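A few compounds are considered here, and "the series" means these few. Any claim that something is new, unique, unknown or untested is made for them only; others in the source may bear on it.

Compound 1 `CC(C)N(C(=O)CCNC(=O)c1ccc(S(C)(=O)=O)c([N+](=O)[O-])c1)C(C)C` gives > 27000 nM in an ADME assay on HepG2 cells (Homo sapiens) for cytotoxicity, read by CellTiter-Glo and ATP content, with a stated time of 72 h (a higher number here means that more compound is needed for the effect, a lower number that less compound is needed), which is a limit of the assay rather than a number.
Compound 2 `CC1CCN(C(=O)CCNC(=O)c2ccc(S(C)(=O)=O)c([N+](=O)[O-])c2)CC1` gives > 27000 nM in this assay, again only a limit.
Compound 3 `CS(=O)(=O)c1ccc(C(=O)NCCCC(=O)N2CCCCC2)cc1[N+](=O)[O-]` gives > 27000 nM in this assay, also a limit.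

Compound 2 therefore stands nowhere in particular on these numbers: it sits at the same limit as the other two, and all three values rest on (the limit of > 27000 nM in this assay, at which 3 of the 3 values shown sit). Because of that, the steps between them cannot be read. The step that the two limits leave unreadable from compound 1 to compound 2 exchanges one amine on the carbonyl carbon for another, and the step that the two limits leave unreadable from compound 2 to compound 3 changes the chain and its amine, as does a step that the two limits leave unreadable from compound 1 to compound 3; none of the three says whether such changes move the read-out.

Compound 4 `CS(=O)(=O)c1ccc(C(=O)NCCC(=O)N2CCc3ccccc32)cc1[N+](=O)[O-]` is the next variation on the same theme. 2,3-dihydro-1H-indol-1-yl in place of 4-methylpiperidin-1-yl on a carbonyl carbon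

Within the data shown here, the steps that bear on this change are those from compound 1 to compound 2 and from compound 2 to compound 3, both unreadable and both compatible with no effect at all. So no step of any size in this assay can be predicted, and the most likely outcome is another limit.

Compound 4 is therefore expected near 30000 nM, with a range from 15000 nM to 100000 nM. The step that the limit leaves unreadable from compound 2 to compound 4 is expected to stay within the scatter.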

Compound 4, half-maximal effective concentration: > 27000 nM
Compound 4: a limit, no number; the forecaster's own chance of this, stated with the estimate: 80%; the middle value lies beyond the limit too.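

No new step can be read: the steps from compound 2 to compound 4 and from compound 1 to compound 4 stay unreadable because compound 4 ends at a limit, as compound 1 and compound 2 do: the limit of > 27000 nM in this assay, at which 4 of the 4 values shown sit.

The compounds shown leave open what concentration of any of them gives the effect in this assay and whether exchanging the amine on the carbonyl carbon changes that read-out at all.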